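A few compounds are considered here, and "the series" means these few. Any claim that something is new, unique, unknown or untested is made for them only; others in the source may bear on it.

Measured so far:
Compound 1 `C[Si](C)(C)c1cn(C[C@H](O)[C@H]2OC(=O)C(OCc3ccccc3)=C2OCc2ccccc2)nn1` gives 24100 nM in a functional assay on HepG2 cells (Homo sapiens) for antiproliferative activity, read by MTT assay, with a stated time of 72 h; on this read-out higher numbers stand for weaker inhibition and lower numbers for stronger inhibition.
Compound 2 `O=C1O/C(=C\Cn2cc(-c3ccc(Br)cc3)nn2)C(OCc2ccccc2)=C1OCc1ccccc1` gives only a limit of the assay in this assay, > 100000 nM.

Among these two results, compound 1 stands as the only one reported as a number; the other result sits at a limit of the assay, (the limit of > 100000 nM in this assay, at which 1 of the 2 values shown sits), and says no more than that. Compound 3 `CCCCCCCCCCc1cn(C[C@H](O)[C@H]2OC(=O)C(OCc3ccccc3)=C2OCc2ccccc2)nn1` has not yet been measured in this assay. It is built on the same core as compound 1 and differs from it in one place: a group of 10 heavy atoms (10 carbon; no ring) in place of a group of 4 heavy atoms (3 carbon, 1 silicon; no ring), on an aromatic carbon. Among the compounds with values here, since no pair of measured compounds differs in a single place, the data give no measured step to lean on for this change. The step of a 1.6-fold lower number from compound 1 to compound 3 (0.21 log units; within the scatter) is therefore expected to be small, close to the usual scatter, leaning toward stronger inhibition. Compound 3 is estimated at 15000 nM, with a range from 4000 nM to 60000 nM.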

Compound 3, half-maximal inhibitory concentration: 12200 nM
For compound 3 the middle estimate is 1.2-fold (0.09 log units) above the measured one, and the stated range covers the measured number.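

In this assay, putting decyl in place of the group of 4 heavy atoms that holds silicon, on the aromatic carbon of the five-membered ring, gives a 2.0-fold lower number from compound 1 to compound 3 (0.30 log units; within the scatter) and leaves the two compounds indistinguishable. This is the first single-place comparison among the compounds shown, and it shows that this position can carry either a silicon-bearing group or a chain of 10 carbon while the reading stays within the same range. Nothing measured here accounts for this similarity. From the compounds shown here alone, whether an amine or a carboxylic acid on this carbon would shift the number beyond the scatter remains open. So does whether a shorter chain such as butyl would read like decyl, since only these two groups can be compared here.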